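The source may report more compounds than this note shows. Statements on the series, on what has been measured and on what is new or still open speak of the compounds shown alone.

Measured compounds in an assay on isolated protein for agonist activity at Bile acid receptor (Homo sapiens), read by AlphaScreen, with a stated time of 30 min; a lower number here means that less compound is needed, a higher number that more compound is needed for the effect:
compound 1 `Cc1ccccc1-n1nc(C)c2c1NC(=O)[C@H](C)S[C@@H]2c1ccc(-c2cccc(C(=O)O)c2)cc1`: "not active" (no number reported)
compound 2 `Cc1ccccc1-n1nc(C)c2c1NC(=O)[C@H](C)S[C@@H]2c1ccc(-c2ccoc2)cc1`: 3500 nM
compound 3 `Cc1ccccc1-n1nc(C)c2c1NC(=O)[C@H](C)S[C@@H]2c1ccc(Oc2ccccc2)cc1`: 1300 nM

Compound 1 carries a 3-carboxyphenyl on the shared core and is reported in this assay as not active, so no single number places it among the others. Going by the values given here, the only step of one change within the measured set is between compound 2 and compound 3: a 2.7-fold lower number from compound 2 to compound 3 (0.43 log units; beyond the scatter). Compound 4 `Cc1ccccc1-n1nc(C)c2c1NC(=O)[C@H](C)S[C@@H]2c1ccc(Oc2ccccc2C(=O)O)cc1` differs from compound 1 by 2-carboxyphenoxy in place of 3-carboxyphenyl on an aromatic carbon.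

The measured step bears on compound 4 only loosely. Among the compounds with values here, it shows that a phenoxy group at this position gives a modest gain over furan-3-yl, but no measured pair carries a carboxylic acid through a phenoxy linkage, and no measured pair sets a carboxyphenyl against a plain phenyl. What is known is that compound 3, with phenoxy alone, gives 1300 nM, whereas compound 1 with a directly attached acid-bearing ring gives no number at all. Compound 4 combines the linkage that helped with the acid that accompanied inactivity, so the expected size of the step in this assay cannot be fixed from the data; a weak result, possibly again only a limit, is expected. Compound 4 is therefore estimated at 6000 nM, within a range of 1500 nM to 25000 nM.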

Compound 4, half-maximal effective concentration: "not active" (no number reported)
Compound 4: no number reported; the estimate stays without a comparison.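

In this assay compound 1 gives "not active" (no number reported) and compound 4 gives "not active" (no number reported), so no new step can be read from this pair. No evidence on hand bears on this result. The compounds shown leave open whether any carboxyl-bearing group at this position on the shared core can give a measurable number in this assay.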